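Acid to Amide: Stability Read Against a Limit

The source may report more compounds than this note shows. Statements on the series, on what has been measured and on what is new or still open speak of the compounds shown alone.

Measured compounds:
compound 1, `CS(=O)(=O)c1ccc(-c2cnc(N)c(-c3ccc(N)nc3)n2)cc1`: > 90%
compound 2, `Nc1ncc(-c2ccc(C(=O)O)cc2)nc1-c1ccc(C(F)(F)F)cc1`: > 90%
compound 3, `Nc1ccc(-c2cnc(N)c(-c3ccc(N)nc3)n2)cn1`: > 90%

In an ADME assay on microsomes from liver (Rattus norvegicus) for metabolic stability, read by LC-MS, using NADPH, with a stated time of 30 min, tested at 0.1 uM, in the presence of a further agent that is not named here (on this read-out lower numbers stand for a less stable compound and higher numbers for a more stable compound), compound 1 gives > 90%, which is a limit of the assay and not a number. Compound 3 likewise gives > 90%, again a limit rather than a number. Compound 2 stands at > 90% in this assay, and this too is a limit and not a number. All readings shown rest on (the limit of > 90% in this assay, at which 3 of the 3 values shown sit), so nothing separates the three measured compounds from one another in this assay, and no compound can be called more or less stable than another.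

Compound 4, `Nc1ncc(-c2ccc(C(=O)N3CCC(O)CC3)cc2)nc1-c1ccc(C(F)(F)F)cc1`, differs from compound 2 by 4-hydroxypiperidin-1-yl in place of hydroxy on a carbonyl carbon. No step between measured compounds is shown, so there is no measured guide to how this change acts in this assay. Since compound 2 and both other measured compounds rest at the limit, the most that can be said is that a tertiary amide bearing a 4-hydroxypiperidin-1-yl group has not been tested here. The step of a number at least 5 percentage points lower from compound 2 to compound 4 (that floor lies within the scatter) is expected to be small, within the usual scatter or only just beyond it. Compound 4 is therefore expected to give about 85%, with a range from 60% to 95%, and a fair chance that the assay again reports only a limit.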

Compound 4, percent of the compound remaining: > 90%
Compound 4 gave a limit, no number; the forecaster's own chance of this, stated with the estimate: 45%; middle value at least 5 percentage points from the limit.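

In this assay compound 4 gives > 90%, which is a limit of the assay and not a number. Going by these compounds alone, no step from compound 2 to compound 4 can be read, because both rest at a limit: the limit of > 90% in this assay, at which 4 of the 4 values shown sit. The compounds shown leave open whether 4-hydroxypiperidin-1-yl in place of hydroxy on a carbonyl carbon changes stability at all.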